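A few compounds are considered here, and "the series" means these few. Any claim that something is new, unique, unknown or untested is made for them only; others in the source may bear on it.

Three compounds share a core in which a nitrile-bearing double bond carries an amide to a dichlorobenzyl group, and differ only in the ring on the far end of that double bond. Compound 1 `N#C/C(=C\c1ccc[nH]1)C(=O)NCc1ccc(Cl)c(Cl)c1` gives 6000 nM in a functional assay on MCF7 cells (Homo sapiens) for inhibition, read by MTT assay, with a stated time of 72 h; a higher number here means a weaker inhibitor of growth, a lower number a stronger inhibitor of growth. Compound 2 `N#C/C(=C\c1ccco1)C(=O)NCc1ccc(Cl)c(Cl)c1` gives 20000 nM in this assay, and compound 3 `N#C/C(=C\c1ccc(Cl)cc1)C(=O)NCc1ccc(Cl)c(Cl)c1` gives 21000 nM in this assay, the highest of the three numbers; a 1.1-fold higher number from compound 2 to compound 3 (0.02 log units; within the scatter), while a 3.5-fold higher number from compound 1 to compound 3 (0.54 log units; beyond the scatter) and a 3.3-fold higher number from compound 1 to compound 2 (0.52 log units; beyond the scatter).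

Compound 4 `COc1ccc(/C=C(\C#N)C(=O)NCc2ccc(Cl)c(Cl)c2)cc1` arises from compound 3 by methoxy in place of chloro on an aromatic carbon. Among the compounds with values here, no measured pair varies a substituent on that phenyl ring; the pairs measured exchange the whole ring, and the one pair that places the chloro-bearing phenyl against another ring, a 1.1-fold higher number from compound 2 to compound 3 (0.02 log units; within the scatter), stayed within the scatter. On that basis a step of a 1.2-fold lower number from compound 3 to compound 4 (0.07 log units; within the scatter) is expected, without a direction beyond the scatter. Compound 4 is therefore estimated at 18000 nM in this assay, with a range from 7000 nM to 45000 nM.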

Compound 4, concentration for 50% growth inhibition: 45000 nM
For compound 4 the middle estimate is 2.5-fold (0.40 log units) below the measured one; the measured number falls inside the stated range.
By their numbers in this assay, from the lowest: compound 1; then compounds 2 and 3 (each within the scatter of the next); then compound 4.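

In this assay the exchange of chloro for methoxy, para to a large group, gives a 2.1-fold higher number from compound 3 to compound 4 (0.33 log units; beyond the scatter) and so shows that a substituent on this phenyl ring can move the number beyond the scatter, something the exchanges of whole rings had not tested. Compound 4 also separates from the furan-2-yl compound, with a 2.3-fold higher number from compound 2 to compound 4 (0.35 log units; beyond the scatter) where compound 3 stayed within the scatter of compound 2, and a 7.5-fold higher number from compound 1 to compound 4 (0.88 log units; beyond the scatter) is the largest step among the four compounds. Nothing available accounts for the step from chloro to methoxy.

From the compounds shown here alone, with only chloro and methoxy on this phenyl ring, it remains open how an amine, a hydroxyl or a carboxylic acid in the same place would read. Going by these compounds, it also remains open whether any such group could bring the phenyl series down to the number of compound 1.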